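Urea series: tert-butyl for methyl on the aryl ring

This account rests on a few compounds, and the source may have more. Where it says the series, first, only, none or still open, it means among the compounds named here.

Working notes. Compound 1 `Cc1ccc(NC(=O)Nc2cc(C)nc3ccccc23)cc1` is taken in an ADME assay on BJ cells (Homo sapiens) for cytotoxicity, with a stated time of 72 h; on this read-out lower numbers stand for an effect already at smaller amounts and higher numbers for an effect only at larger amounts of compound. In this assay compound 1 gives > 25000 nM, which is a limit of the assay rather than a number. Two neighbours share the core. Compound 2 `Cc1cc(NC(=O)Nc2ccccc2F)c2ccccc2n1` gives in this assay > 25000 nM, again a limit. Compound 3 `Cc1cc(NC(=O)Nc2cccc(C(C)(C)C)c2)c2ccccc2n1` gives in this assay > 25000 nM, also a limit. Compound 1 thus stands at the limit with no number of its own, and every value shown sits at the limit of > 25000 nM in this assay, at which 3 of the 3 values shown sit. Within the data shown here, the one step within the set, a step that the two limits leave unreadable from compound 1 to compound 2, has two limits as its ends and cannot be read.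

Compound 4 `Cc1cc(NC(=O)Nc2ccc(C(C)(C)C)cc2)c2ccccc2n1` differs from compound 1 as follows: tert-butyl in place of methyl on an aromatic carbon. Among the measured compounds shown here, only the step from compound 1 to compound 2 bears on this change, and its size is not readable. Compound 3 also carries a tert-butyl group and its value is likewise only a limit, so nothing in the set points to an effect reaching the measured range. The step expected in this assay is a step that the limit leaves unreadable from compound 1 to compound 4, none beyond the scatter. For compound 4 the expected value in this assay is 30000 nM, within 18000 nM to 60000 nM, most likely again reported as a limit.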

Compound 4, half-maximal effective concentration: 20000 nM
Estimate against measurement, compound 4: 1.5-fold (0.18 log units) above; measured number inside the range.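

In this assay, among these compounds, the place on the aromatic carbon para to a large group yields the first actual number, with tert-butyl there: compound 4 gives 20000 nM. Tert-butyl in place of methyl produces an at least 1.2-fold lower number from compound 1 to compound 4 (0.09 log units; that floor lies within the scatter), so this position and this change show only a small floor for the step, not a shift established beyond the usual scatter. The true size of the step stays unknown because one of its ends is still a limit of the assay: the limit of > 25000 nM in this assay, at which 3 of the 4 values shown sit.

From the compounds shown here alone, compound 3 also carries tert-butyl on the aromatic ring yet stands only at a limit, so it remains open whether the number for compound 4 goes with the group itself or with its place on the ring. Going by these compounds, the step between compound 1 and compound 2 cannot be read, and how an amine, a carboxylic acid or a longer chain in place of tert-butyl on the same aromatic carbon would read in this assay also remains open.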